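A few compounds are considered here, and "the series" means these few. Any claim that something is new, unique, unknown or untested is made for them only; others in the source may bear on it.

Working notes on the series. Two compounds carry numbers in an assay on HeLa cells for displacement of a labelled ligand from 5-hydroxytryptamine receptor 6 (Homo sapiens); on this read-out higher numbers stand for weaker inhibition and lower numbers for stronger inhibition. In this assay compound 1 `COc1ccc(S(=O)(=O)c2n[nH]c3cc(N4CCNCC4)ccc23)cc1` gives 124 nM. In this assay, among the compounds with values here, compound 2 `CN1CCN(c2ccc3c(c2)c(S(=O)(=O)c2cccc4ccccc24)nn3Cc2ccccc2)CC1` gives 2 nM, the lowest of the two numbers; the only other value, that of compound 1, lies far above it, and the gap between the two is beyond the scatter. The two compounds differ in several places at once, so no single change can be credited with that gap.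

Compound 3 `CC(C)n1nc(S(=O)(=O)c2cccc3ccccc23)c2cc(N3CCN(C)CC3)ccc21` is not yet measured. It differs from compound 2 in one place: isopropyl in place of benzyl on an aromatic nitrogen

Within the data shown here, no pair of measured compounds shows how the group on this aromatic nitrogen moves the number, so the size of the step can only be estimated. A moderate rise is expected, that is a weakening, but close to the edge of what repeated runs resolve; the expected step is a 3.0-fold higher number from compound 2 to compound 3 (0.48 log units; beyond the scatter). Compound 3 is expected to give about 6 nM in this assay, with a plausible range from 1.5 nM to 25 nM.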

Compound 3, inhibition constant: 1.8 nM
Compound 3: middle estimate off by 3.3-fold (0.52 log units), on the high side; the measured number falls inside the stated range.
By their numbers in this assay, from the lowest: compounds 3 and 2 (each within the scatter of the next); then compound 1.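

Within the data shown here, the step of a 1.1-fold lower number from compound 2 to compound 3 (0.05 log units; within the scatter) in this assay is the first reading of this position on its own. All else in the two structures is shared. With isopropyl in place of benzyl on the aromatic nitrogen, the six-membered aromatic ring of the benzyl group leaves and the number stays within what repeated runs cannot separate, so in this pair the group at this place does not need an aromatic ring to hold a low number in this assay. No accompanying measurement explains why the two groups read alike.

Still open, going by these compounds, is whether a group carrying an amine or a carboxylic acid, or a longer chain, on this aromatic nitrogen would read the same way as benzyl and isopropyl. Also open, on these data alone, is whether these two groups stay level when another part of the molecule changes, since the comparison rests on a single background.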